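A few compounds are considered here, and "the series" means these few. Any claim that something is new, unique, unknown or untested is made for them only; others in the source may bear on it.

Working notes on the series. In an ADME assay on Caco-2 cells (Homo sapiens) for permeability, in the apical to basolateral direction (a lower number here means that the compound crosses the layer more slowly, a higher number that the compound crosses the layer faster), compound 1 (`C[C@@H](CO)Oc1cc(Oc2ccc(C(=O)N(C)C)cc2)cc(C(=O)Nc2ccn(C)n2)c1`) gives 17 nm/s and compound 2 (`COC[C@H](C)Oc1cc(Oc2ccc(C(=O)N(C)C)cc2)cc(C(=O)Nc2cc[nH]n2)c1`) gives 23 nm/s in the same read-out. For the measured compounds named here, these two values lie within the scatter of each other, so compound 1 holds no separate place on the numbers so far. Going by the values given here, the series also holds no measured pair that differs in one place, so no measured step is available to set the size of the next one.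

Compound 3 (`C[C@@H](CO)Oc1cc(Oc2ccc(C(=O)N3CCC3)cc2)cc(C(=O)Nc2ccn(C)n2)c1`) has not yet been measured. It differs from compound 1 in one place: azetidin-1-yl in place of dimethylamino on a carbonyl carbon. The rest of the core of compound 1 is kept.

The expectation therefore starts from compound 1 at 17 nm/s and rests otherwise on the structural change alone. No shift beyond the scatter is expected in either direction. The estimated 1.2-fold higher number from compound 1 to compound 3 (0.07 log units; within the scatter) is small and stays within the scatter. For compound 3 the estimate is 20 nm/s in this assay, with 9 nm/s to 42 nm/s as the expected range.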

Compound 3, apparent permeability in the Caco-2 assay: 18 nm/s
Estimate against measurement, compound 3: 1.1-fold (0.05 log units) above; measured number inside the range.
By their numbers in the Caco-2 assay, from the lowest: compounds 1, 3 and 2 (each within the scatter of the next).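

This series now has its first measured one-place step, on a carbonyl carbon whose other neighbour is an aromatic carbon: in the Caco-2 assay the step reads a 1.1-fold higher number from compound 1 to compound 3 (0.02 log units; within the scatter) and does not separate the two compounds, so azetidin-1-yl in place of dimethylamino leaves them level in this read-out. The same change does separate them in a physicochemical assay for solubility (a lower number here means a less soluble compound, a higher number a more soluble compound), where the step reads an at least 2.8-fold lower number from compound 1 to compound 3 (0.45 log units; beyond the scatter) and compound 3 gives 350000 nM as a true number. In the physicochemical assay compound 1 gives > 1000000 nM, which is a limit of the assay and not a number. The size of that step is only a bound, because compound 1 stands at a limit of the assay rather than at a number: the limit of > 1000000 nM in the physicochemical assay, at which 1 of the 2 values shown sits.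

Going by these compounds, how pyrrolidin-1-yl or morpholin-4-yl on the same carbonyl carbon would read in the Caco-2 assay or the physicochemical assay remains open, and with it whether the split between the two read-outs holds beyond this single change. Compound 2 has no partner among the compounds shown that differs from it in one place, so its differences from compound 1 cannot be taken apart.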